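From 3-fluorophenyl to 4-aminophenyl on a shared core

The source may report more compounds than this note shows. Statements on the series, on what has been measured and on what is new or still open speak of the compounds shown alone.

Measured in a functional assay on MCF7 cells (Homo sapiens) for inhibition, read by trypan blue exclusion, with a stated time of 3 days; a higher number here means a weaker inhibitor, a lower number a stronger inhibitor:
Compound 1 `COc1cc(C(=O)c2cn(-c3ccccc3)cc2-c2cccc(C)c2)cc(OC)c1OC`: 450 nM
Compound 2 `COc1cc(C(=O)c2cn(-c3ccccc3)cc2-c2cccc(F)c2)cc(OC)c1OC`: 57 nM
Compound 3 `COc1cc(C(=O)c2cn(-c3ccccc3)cc2-c2ccc(C)cc2)cc(OC)c1OC`: 280 nM

Among these three, compound 2 is the strongest inhibitor in this assay, at 57 nM. The unmeasured compound 4 `COc1cc(C(=O)c2cn(-c3ccccc3)cc2-c2ccc(N)cc2)cc(OC)c1OC` carries 4-aminophenyl in place of the 3-fluorophenyl of compound 2, on an aromatic carbon of a five-membered aromatic ring with 1 nitrogen: 4-aminophenyl in place of 3-fluorophenyl on an aromatic carbon.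

Among the measured compounds shown here, three measured steps bear on this change. Replacing 3-fluorophenyl with 4-methylphenyl gave a 4.9-fold higher number from compound 2 to compound 3 (0.69 log units; beyond the scatter). Fluoro in place of methyl gave a 7.9-fold lower number from compound 1 to compound 2 (0.90 log units; beyond the scatter). Exchanging 3-methylphenyl for 4-methylphenyl gave a 1.6-fold lower number from compound 1 to compound 3 (0.21 log units; within the scatter). For the measured compounds named here, no measured compound carries an amino group, so the comparison is indirect. Compound 3, at 280 nM, is the closest measured match, since it also has a group named at the 4 place of the phenyl, and a higher number than that of compound 2 is therefore expected, though perhaps a smaller rise. The expected step is a 2.6-fold higher number from compound 2 to compound 4 (0.42 log units; beyond the scatter). For compound 4 the estimate is 150 nM, with an expected range of 30 nM to 700 nM.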

Compound 4, half-maximal inhibitory concentration: 9 nM
Beside the measured number, compound 4's estimate is 17-fold (1.22 log units) above it; the measured number lies below the stated range.
By their numbers in this assay, from the lowest: compound 4; then compound 2; then compounds 3 and 1 (each within the scatter of the next).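

Earlier, 4-methylphenyl on this aromatic carbon had given a weaker inhibitor than 3-fluorophenyl, but in this assay 4-aminophenyl reverses that direction, with a 6.3-fold lower number from compound 2 to compound 4 (0.80 log units; beyond the scatter) in place of a rise. Changing only methyl to amino gives a 31-fold lower number from compound 3 to compound 4 (1.49 log units; beyond the scatter) and the step from 3-methylphenyl gives a 50-fold lower number from compound 1 to compound 4 (1.70 log units; beyond the scatter), so at this position the outcome depends strongly on which group the phenyl carries, not only on where that group stands. Nothing at hand accounts for the size of these steps.

Going by these compounds, whether 3-aminophenyl would match 4-aminophenyl here remains open, as does the outcome with 4-hydroxyphenyl, 4-fluorophenyl or a 4-(methylamino)phenyl group. Also open, on these data alone, is whether the amino group would give a similar step if the phenyl on the ring nitrogen were changed.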